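This account rests on a few compounds, and the source may have more. Where it says the series, first, only, none or still open, it means among the compounds named here.

In a functional assay on IMR-32 cells (Homo sapiens) for antiproliferative activity, read by MTT assay (on this read-out higher numbers stand for weaker inhibition and lower numbers for stronger inhibition), compound 1 `CC1(C)CCc2cc(C(=O)/C=C/c3ccc(OCc4cn(-c5ccc(Cl)cc5)nn4)cc3)c(O)cc2O1` gives 92100 nM and compound 2 `Cc1c(-n2cc(COc3ccc(/C=C/C(=O)c4ccc5c(c4O)CCC(C)(C)O5)cc3)nn2)cccc1[N+](=O)[O-]` gives 73500 nM within the scatter of compound 1. Compound 3 `CCCCCn1cc(COc2ccc(/C=C/C(=O)c3ccc4c(c3O)CCC(C)(C)O4)cc2)nn1` carries pentyl in place of 2-methyl-3-nitrophenyl on an aromatic nitrogen and is otherwise the same as compound 2. Among the compounds with values here, no measured step sizes this change, and no shift beyond the scatter is expected for it in this assay on present data. The estimated step of a 1.2-fold lower number from compound 2 to compound 3 (0.09 log units; within the scatter) is expected to stay within the scatter. Compound 3 is estimated at 60000 nM with an expected range from 25000 nM to 140000 nM in this read-out.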

Compound 3, half-maximal inhibitory concentration: "not active" (no number reported)
Nothing numeric was reported for compound 3, and the estimate cannot be compared.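

Within the data shown here, compound 3 is reported as not active in this assay without a number, so no step from compound 2 to compound 3 can be read. The compounds shown leave open how pentyl in place of 2-methyl-3-nitrophenyl shifts the read-out. Nothing further on hand bears on this result.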